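Straight chain to branched chain on compound 2

The source may hold more compounds than are shown below. What is called first, only, known or untested is meant among the compounds shown, and "the series" means these compounds.

Compound 1 `C[C@H]1O[C@@H](n2cc(F)c(NC(=O)Oc3ccc(Cl)cc3)nc2=O)[C@H](O)[C@@H]1O` gives 100 ug/mL
Compound 2 `CCCCCOC(=O)Nc1nc(=O)n([C@@H]2O[C@H](C)[C@H]3OC(=O)O[C@H]32)cc1F` gives 80 ug/mL

In a functional assay on MCF7 cells (Homo sapiens) for cytotoxicity, read by MTT assay, with a stated time of 3 days (a lower number here means a stronger inhibitor, a higher number a weaker inhibitor), compound 2 gives 80 ug/mL and compound 1 gives 100 ug/mL so the two lie within the usual scatter of each other. Neither can be called the stronger inhibitor.

Compound 3 `CCC(C)COC(=O)Nc1nc(=O)n([C@@H]2O[C@H](C)[C@H]3OC(=O)O[C@H]32)cc1F` differs from compound 2 in one place: sec-butyl in place of butyl on a saturated chain carbon bound to an oxygen next to a carbonyl group on a saturated chain carbon bound to an oxygen next to a carbonyl group. The two have the same atoms, joined differently, and cut one bond further out the change reads pentyloxy to 2-methylbutoxy.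

Going by the values given here, no measured pair here shows what this change does, so no shift beyond the scatter is expected in this assay in either direction. The estimated change is no change at the digits printed from compound 2 to compound 3 (within the scatter) and it stays within the scatter. For compound 3 the estimate is 80 ug/mL with an expected range from 45 ug/mL to 140 ug/mL in this measurement.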

Compound 3, half-maximal inhibitory concentration: 70 ug/mL
Compound 3: the middle estimate sits 1.1-fold (0.06 log units) above what was measured; low and high end bracket the measured number.
By their numbers in this assay, from the lowest: compounds 3, 2 and 1 (each within the scatter of the next).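

Going by these compounds alone, the first measured pair for this change gives a reading in this assay: a 1.1-fold lower number from compound 2 to compound 3 (0.06 log units; within the scatter), so compounds 2 and 3 cannot be told apart here. On a saturated chain carbon bound to an oxygen next to a carbonyl group, the same atoms can therefore be rejoined from pentyloxy into 2-methylbutoxy without a shift beyond the scatter, at least for this single pair. Nothing available explains this result, and the reading itself gives no reason for it.

Still open, from the compounds shown here alone, is whether a longer chain such as decyl, or a chain ending in an amine or a carboxylic acid, would move the number beyond the scatter. Going by these compounds, it is equally open whether a more heavily branched group, such as tert-butyl, or a ring, such as cyclohexyl, would leave the reading as unchanged as sec-butyl does.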